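Replacing an Aminomethylphenyl Ketone with a Phenethyl Ketone

A few compounds are considered here, and "the series" means these few. Any claim that something is new, unique, unknown or untested is made for them only; others in the source may bear on it.

Of the compounds shown here, three sharing one core have been tested in an ADME assay on L929 cells (Mus musculus) for cytotoxicity, read by resazurin assay, with a stated time of 72 h; on this read-out higher numbers stand for weaker inhibition and lower numbers for stronger inhibition. Compound 1 `Cc1cccc(C(=O)c2ccn(-c3ccc4c(c3)B(O)OC4)c2)c1` gives in this assay the value > 10 ug/mL, which is a limit of the assay rather than a number. Compound 2 `CCc1ccc(C(=O)c2ccn(-c3ccc4c(c3)B(O)OC4)c2)cc1` gives > 10 ug/mL, again a limit. Compound 3 `NCc1ccc(C(=O)c2ccn(-c3ccc4c(c3)B(O)OC4)c2)cc1` gives > 10 ug/mL, also a limit. Compound 3 thus stands where all measured compounds stand, at the limit of > 10 ug/mL in this assay, at which 3 of the 3 values shown sit. The steps a step that the two limits leave unreadable from compound 1 to compound 3 and a step that the two limits leave unreadable from compound 2 to compound 3 bear on the change considered here, yet each joins two limits and its size cannot be read; the same holds for a step that the two limits leave unreadable from compound 1 to compound 2.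

Compound 4 `O=C(CCc1ccccc1)c1ccn(-c2ccc3c(c2)B(O)OC3)c1` differs from compound 3 by phenethyl in place of 4-(aminomethyl)phenyl on a carbonyl carbon. With every measured step around compound 3 unreadable, no direction beyond the scatter is expected from the change. Compound 4 is expected to give in this assay about 15 ug/mL, within a range from 7 ug/mL to 40 ug/mL, and most probably again as a limit. The expected step that the limit leaves unreadable from compound 3 to compound 4 is estimated to lie within the scatter.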

Compound 4, half-maximal inhibitory concentration: > 10 ug/mL
Compound 4 was reported as a limit; the forecaster's own chance of this, stated with the estimate: 80%; the middle value is on the limit's open side.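

No new step can be read, since the steps joining compound 4 to compound 1, compound 2 and compound 3 each link two limits: the limit of > 10 ug/mL in this assay, at which 4 of the 4 values shown sit.

The compounds shown leave open how far compound 1, compound 2, compound 3 and compound 4 actually lie from one another in this assay.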